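Swapping Chloro for Iodo on the Shared Core

The source may report more compounds than this note shows. Statements on the series, on what has been measured and on what is new or still open speak of the compounds shown alone.

Two related compounds have been tested in a functional assay on MT4 cells (Homo sapiens) for cytotoxicity; a lower number here means that less compound is tolerated, a higher number that more compound is tolerated. Compound 1 `C=CCC1=C(N)[C@@]2(OS1(=O)=O)[C@@H](CO[Si](C)(C)C(C)(C)C)O[C@@H](n1cc(C)c(=O)n(C)c1=O)[C@@H]2O[Si](C)(C)C(C)(C)C` gives 82000 nM. Compound 2 `Cc1cn([C@@H]2O[C@H](CO[Si](C)(C)C(C)(C)C)[C@@]3(OS(=O)(=O)C(Cl)=C3N)[C@H]2O[Si](C)(C)C(C)(C)C)c(=O)[nH]c1=O` gives 5400 nM, the lowest of the two numbers; the nearest figure is that of compound 1, which is higher by a gap beyond the usual scatter, so compound 2 is tolerated only at a lower concentration than compound 1. The next compound, compound 3 `Cc1cn([C@@H]2O[C@H](CO[Si](C)(C)C(C)(C)C)[C@@]3(OS(=O)(=O)C(I)=C3N)[C@H]2O[Si](C)(C)C(C)(C)C)c(=O)[nH]c1=O`, has not yet been measured. It differs from compound 2 in one place: iodo in place of chloro on a double-bonded ring carbon. No comparable change between measured compounds is available to guide the outcome. The expectation is a step of a 1.1-fold lower number from compound 2 to compound 3 (0.03 log units; within the scatter) that stays within the usual scatter, in no clear direction. For compound 3 the estimated half-maximal cytotoxic concentration in this assay is 5000 nM, with a range from 1500 nM to 16000 nM.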

Compound 3, half-maximal cytotoxic concentration: 4300 nM
Compound 3: middle estimate off by 1.2-fold (0.07 log units), on the high side; the range from low to high includes it.
By their numbers in this assay, from the lowest: compounds 3 and 2 (each within the scatter of the next); then compound 1.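

In this assay, iodo in place of chloro on a double-bonded ring carbon gives a 1.3-fold lower number from compound 2 to compound 3 (0.10 log units; within the scatter), so the two compounds cannot be told apart in this measurement. Compound 1 and compound 2 differ in more than one place, which made it impossible to read this position alone; this pair isolates it and shows that this swap leaves the cytotoxicity read-out within the scatter. No measurement at hand offers an explanation for this result.

On these data alone, whether a nitrile, a carboxylic acid or an amine on this same carbon would move the number beyond the scatter remains open. Also open, as far as these compounds go, is whether chloro and iodo would stay this close if the other features of the shared core were changed.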